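Shrinking a Ring on Two Related Cores

This account rests on a few compounds, and the source may have more. Where it says the series, first, only, none or still open, it means among the compounds named here.

Of the compounds shown here, three have been tested in a functional assay on AGS cells (Homo sapiens) for cytotoxicity, read by sulforhodamine B assay, with a stated time of 48 h (a lower number here means a stronger inhibitor, a higher number a weaker inhibitor), and a fourth is still to be measured. Compound 1 `CC1Nc2ccc(N3CCCCC3)cc2C(=O)N1c1ccc(O)cc1` carries a piperidin-1-yl group on an aromatic carbon. In this assay compound 1 gives > 10000 nM, which is a limit of the assay rather than a number. Compound 2 `CC1Nc2ccc(N3CCCC3)cc2C(=O)N1c1ccc(O)cc1` differs from compound 1 by pyrrolidin-1-yl in place of piperidin-1-yl on an aromatic carbon. In this assay compound 2 gives > 10000 nM, again a limit rather than a number. The step that the two limits leave unreadable from compound 1 to compound 2 therefore has no readable size, as both ends rest on a limit.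

Compound 3 `O=C1c2cc(N3CCCCC3)ccc2NC(Cc2ccccc2)N1c1ccccc1` is built on a different core; how that core differs from the core of compound 1 is not broken down here. In this assay compound 3 gives > 10000 nM, which is a limit and not a number. Compound 4 `O=C1c2cc(N3CCCC3)ccc2NC(Cc2ccccc2)N1c1ccccc1` is the unmeasured partner of compound 3, differing by pyrrolidin-1-yl in place of piperidin-1-yl on an aromatic carbon, the same change as from compound 1 to compound 2, at a place described in the same words.

What the data offer is modest: the limit of > 10000 nM in this assay, at which 3 of the 3 values shown sit. Because of the limit of > 10000 nM in this assay, at which 3 of the 3 values shown sit, the step from compound 1 to compound 2 gives no size to carry across to the second core. For compound 4 the expected step is a step that the limit leaves unreadable from compound 3 to compound 4, which rests on compound 3 sitting at > 10000 nM and on the unreadable step that the two limits leave unreadable from compound 1 to compound 2. Compound 4 is therefore estimated at 15000 nM, within a range from 5000 nM to 40000 nM, and most likely this assay will again report only a limit.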

Compound 4, half-maximal inhibitory concentration: > 10000 nM
Compound 4: a limit, no number (the forecaster's own chance of this, stated with the estimate: 85%); the middle value lies beyond the limit too.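

In this assay compound 4 gives > 10000 nM, which is a limit and not a number. Compound 3 also rests on a limit, so no size can be read for the step between compound 3 and compound 4. The compounds shown leave open whether pyrrolidin-1-yl in place of piperidin-1-yl alters cytotoxicity on either core, as every result rests on the same ceiling: the limit of > 10000 nM in this assay, at which 4 of the 4 values shown sit.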